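Naphthyloxyacetyl hydrazones in a cytotoxicity test

The source may report more compounds than this note shows. Statements on the series, on what has been measured and on what is new or still open speak of the compounds shown alone.

Compound 1 `C/C(=N\NC(=O)COc1cccc2ccccc12)c1ccc(C#N)cc1Br`: 12.1 ug/mL
Compound 2 `COc1cc(/C=N/NC(=O)COc2cccc3ccccc23)cc(OC)c1OC`: 13.4 ug/mL
Compound 3 `O=C(COc1cccc2ccccc12)N/N=C/c1cccc([N+](=O)[O-])c1`: 12.1 ug/mL

Three compounds sharing the same core were examined in an ADME assay on MT4 cells (Homo sapiens) for cytotoxicity, read by MTT assay, with a stated time of 4 days; on this read-out higher numbers stand for lower toxicity in this test and lower numbers for higher toxicity in this test. Compound 1 gives 12.1 ug/mL in this assay, compound 2 gives 13.4 ug/mL and compound 3 gives 12.1 ug/mL. Compound 1 and compound 3 are level at the digits shown, and the gap from compound 1 to compound 2 is also within the scatter, so the three numbers cannot be told apart.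

The next compound, compound 4 `C/C(=N\NC(=O)COc1cccc2ccccc12)c1ccc(O)cc1`, has not yet been measured in this assay. It differs from compound 1 in one place: 4-hydroxyphenyl in place of 2-bromo-4-cyanophenyl on a carbon with a double bond to nitrogen. Among the measured compounds shown here, no step between two measured compounds with this kind of change is available, so the expectation rests on the closeness of the three numbers seen so far. Given that compound 1 gives 12.1 ug/mL and the others lie within the scatter of it, the step of a 1.2-fold higher number from compound 1 to compound 4 (0.09 log units; within the scatter) is expected to be small, with a slight lean toward a higher number. Compound 4 is therefore estimated at 15 ug/mL in this assay, within a range from 7 ug/mL to 35 ug/mL.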

Compound 4, half-maximal cytotoxic concentration: 68.8 ug/mL
The estimate for compound 4 lay 4.6-fold (0.66 log units) below the measured number; measured number above the stated range.
By their numbers in this assay, from the lowest: compounds 1, 3 and 2 (each within the scatter of the next); then compound 4.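

In this assay, the replacement of 2-bromo-4-cyanophenyl by 4-hydroxyphenyl on a carbon with a double bond to nitrogen gives a 5.7-fold higher number from compound 1 to compound 4 (0.75 log units; beyond the scatter). This shows that a change at this place can move the number beyond the scatter, which the three earlier compounds, all within the scatter of one another, could not show. The change removes the bromine and the nitrile and adds a hydrogen-bond donor in a single step, and nothing measured here accounts for the step.

As far as these compounds go, it remains open whether the hydroxyl, the loss of the bromine or the loss of the nitrile carries the step. From the compounds shown here alone, it is also open whether 4-methoxyphenyl or plain phenyl at this place would stand closer to compound 1 or to compound 4.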